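The source may hold more compounds than are shown below. What is called first, only, known or untested is meant among the compounds shown, and "the series" means these compounds.

Measured so far in a functional assay for inhibition, tested at 20 ug/mL; on this read-out lower numbers stand for a weaker effect and higher numbers for a stronger effect at the one concentration tested:
compound 1 `Cc1cc(O)c(C(C)C)cc1-c1cc(-c2ccccc2)c(C#N)c(=O)[nH]1`: 22%
compound 2 `COc1cccc(-c2cc(-c3cc(C(C)C)c(O)cc3C)[nH]c(=O)c2C#N)c1`: 22%
compound 3 `Cc1cc(O)c(C(C)C)cc1-c1cc(-c2cccs2)c(C#N)c(=O)[nH]1`: 26%

For the measured compounds named here, compound 3 is the one with the largest number, but it is not set apart: a number 4 percentage points higher from compound 1 to compound 3 (within the scatter) and a number 4 percentage points higher from compound 2 to compound 3 (within the scatter) both lie within the scatter, as does no change at the digits printed from compound 1 to compound 2 (within the scatter). On the numbers shown, the three compounds sit together, and neither the methoxy on the aromatic carbon nor the change of ring at that position has produced a step beyond the scatter.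

Compound 4 `COc1ccc(-c2cc(-c3cc(C(C)C)c(O)cc3C)[nH]c(=O)c2C#N)cc1` is not yet measured. It differs from compound 3 as follows: 4-methoxyphenyl in place of thiophen-2-yl on an aromatic carbon

Going by the values given here, the steps that bear on this are the exchange of a six-membered carbon ring for the thiophen-2-yl ring, a number 4 percentage points higher from compound 1 to compound 3 (within the scatter) and a number 4 percentage points higher from compound 2 to compound 3 (within the scatter), and the addition of a methoxy, no change at the digits printed from compound 1 to compound 2 (within the scatter); none went beyond the scatter. Going back from thiophen-2-yl to a methoxy-bearing phenyl is therefore expected to give no step beyond the scatter in this assay, and the expected step is a number 4 percentage points lower from compound 3 to compound 4 (within the scatter). Compound 4 is estimated at 22%, with a range from 12% to 32%.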

Compound 4, a percentage reported as inhibition, at one concentration (the size of the read-out at that concentration, not a potency): 24%
Estimate against measurement, compound 4: 2 percentage points below; low and high end bracket the measured number.
By their numbers in this assay, from the lowest: compounds 1, 2, 4 and 3 (each within the scatter of the next).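

At the aromatic carbon opposite the ring nitrogen, this assay now covers phenyl, 3-methoxyphenyl, 4-methoxyphenyl and thiophen-2-yl with no step beyond the scatter: the move to 4-methoxyphenyl from 3-methoxyphenyl gives a number 2 percentage points higher from compound 2 to compound 4 (within the scatter), and methoxy in place of hydrogen at this new ring place gives a number 2 percentage points higher from compound 1 to compound 4 (within the scatter). Exchanging thiophen-2-yl, with 5 heavy atoms, for 4-methoxyphenyl, with 8, gives a number 2 percentage points lower from compound 3 to compound 4 (within the scatter), so neither this change of ring and size nor the place of the methoxy separates these compounds. No measured evidence bears on why these groups read alike.

As far as these compounds go, whether an amine or a carboxylic acid on the phenyl ring, or a longer chain in place of the ring, would give a step beyond the scatter remains open. From the compounds shown here alone, all these numbers come from a single concentration, so any difference in potency also remains open.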